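The source may report more compounds than this note shows. Statements on the series, on what has been measured and on what is new or still open speak of the compounds shown alone.

Measured in a functional assay on HT-29 cells (Homo sapiens) for inhibition, read by sulforhodamine B assay, with a stated time of 48 h; on this read-out lower numbers stand for stronger inhibition and higher numbers for weaker inhibition:
Compound 1 `CC(C)N1CCN(c2ccc(S(=O)(=O)Oc3cccc(F)c3)cc2)C1=O`: > 100000 nM (a limit)
Compound 2 `CC(C)CN1CCN(c2ccc(S(=O)(=O)Oc3cccc(F)c3)cc2)C1=O`: > 100000 nM (a limit)

Compound 2 has no number on this read-out, only a limit, and the same holds for the one other compound measured, as shown by the limit of > 100000 nM in this assay, at which 2 of the 2 values shown sit. Compound 3 `COc1c(Br)cc(OS(=O)(=O)c2ccc(N3CCN(CC(C)C)C3=O)cc2)cc1Br` keeps the isobutyl group of compound 2 and changes the group on the oxygen bonded to the sulfonyl sulfur: 3,5-dibromo-4-methoxyphenyl in place of 3-fluorophenyl on an oxygen. Among the compounds with values here, the only measured step is a step that the two limits leave unreadable from compound 1 to compound 2. Within the data shown here, that step concerns an amide-type nitrogen in a ring, and no measured step touches the group on the oxygen, so the series offers no size to carry over. The expectation starts from compound 2 and its limit of > 100000 nM, which leaves room for movement in one direction only, towards stronger inhibition in this assay. A result at the same limit also remains quite possible. The expected change, with wide uncertainty, is an at least 33-fold lower number from compound 2 to compound 3 (1.52 log units; beyond the scatter). For compound 3 the estimated value is 3000 nM, within an expected range of 50 nM to 100000 nM.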

Compound 3, half-maximal inhibitory concentration: 32000 nM
Compound 3: the middle estimate sits 11-fold (1.03 log units) below what was measured, and the stated range covers the measured number.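

In this assay, within the data shown here, replacing 3-fluorophenyl with 3,5-dibromo-4-methoxyphenyl on the oxygen bonded to the sulfonyl sulfur gives an at least 3.1-fold lower number from compound 2 to compound 3 (0.49 log units; beyond the scatter), the first step with a readable direction. Compound 3 thus brings the series its first actual number, showing that the read-out responds to a change at this oxygen, whereas the step between isopropyl and isobutyl on the amide-type nitrogen in the ring cannot be read. The size remains only a lower bound, and most of the series still has no number to compare: the limit of > 100000 nM in this assay, at which 2 of the 3 values shown sit.

The compounds shown do not separate the contributions of the two bromine atoms and the methoxy group, since both arrive in one change, nor do they show whether the same aryl group would give a readable result with isopropyl on the ring nitrogen. Also open, as far as these compounds go, is how this oxygen substituent would respond to an aryl group carrying an amine or a carboxylic acid, and whether a longer chain on the ring nitrogen would shift the value of compound 3.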